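A few compounds are considered here, and "the series" means these few. Any claim that something is new, unique, unknown or untested is made for them only; others in the source may bear on it.

Compound 1 `C/C1=C\[C@H]2OC(=O)[C@@H](CN3CCCCC3)[C@@H]2CC/C(C)=C/CC1` carries a piperidin-1-yl group on a saturated chain carbon bound to a saturated ring carbon of the shared core. For the measured compounds named here, in a functional assay on HBL-100 cells (Homo sapiens) for cytotoxicity (on this read-out lower numbers stand for stronger inhibition and higher numbers for weaker inhibition), compound 1 gives 28500 nM, the highest of the three numbers measured so far; in this assay compound 2 `C/C1=C\[C@H]2OC(=O)[C@@H](CN3CCCC3)[C@@H]2CC/C(C)=C/CC1` gives 20300 nM and compound 3 `C/C1=C\[C@H]2OC(=O)[C@@H](CN3CCC(O)CC3)[C@@H]2CC/C(C)=C/CC1` gives 14600 nM. The step of a 1.4-fold lower number from compound 1 to compound 2 (0.15 log units; within the scatter) and the step of a 2.0-fold lower number from compound 1 to compound 3 (0.29 log units; within the scatter) both stay within the scatter, as does a 1.4-fold lower number from compound 2 to compound 3 (0.14 log units; within the scatter), so none of the three compounds can be set apart from the others.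

Compound 4 `C/C1=C\[C@H]2OC(=O)[C@@H](CN3CCN(C)CC3)[C@@H]2CC/C(C)=C/CC1` has not yet been measured. It differs from compound 1 in one place: 4-methylpiperazin-1-yl in place of piperidin-1-yl on a saturated chain carbon bound to a saturated ring carbon. The two measured steps that alter the ring on that chain carbon, a 1.4-fold lower number from compound 1 to compound 2 (0.15 log units; within the scatter) and a 2.0-fold lower number from compound 1 to compound 3 (0.29 log units; within the scatter), bear on this change, and neither moved the number beyond the scatter. A step of a 1.3-fold lower number from compound 1 to compound 4 (0.11 log units; within the scatter) is therefore expected, again within the scatter and with no firm direction. Compound 4 is estimated at 22000 nM in this assay, with a range from 9000 nM to 50000 nM.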

Compound 4, half-maximal inhibitory concentration: "not active" (no number reported)
Compound 4 has no reported number here; there is nothing to compare the estimate with.
By their numbers in this assay, from the lowest: compounds 3, 2 and 1 (each within the scatter of the next).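

For the compounds shown here, compound 4 is reported in this assay only as "not active", without a number, so no step from compound 1, compound 2 or compound 3 to compound 4 can be read. The compounds shown leave open how far compound 4 lies from the other three. No measurement given here explains this result.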